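The source may report more compounds than this note shows. Statements on the series, on what has been measured and on what is new or still open speak of the compounds shown alone.

Compound 1 `Oc1ccc(-c2cc(-c3ccco3)cc(-c3ccccc3O)n2)cc1` and compound 2 `Oc1ccc(-c2cc(-c3ccco3)cc(-c3cccc(O)c3)n2)cc1` share a core and differ only in one hydroxyphenyl group. In a functional assay on DU-145 cells (Homo sapiens) for cytotoxicity, read by CCK-8 assay (a higher number here means a weaker inhibitor, a lower number a stronger inhibitor), compound 1 gives only a limit of the assay, > 50000 nM. In this assay compound 2 gives 2070 nM. The change from compound 1 to compound 2 is 3-hydroxyphenyl in place of 2-hydroxyphenyl on an aromatic carbon, and it produced an at least 24-fold lower number from compound 1 to compound 2 (1.38 log units; beyond the scatter). The limit for compound 1 is one of those noted in the limit of > 50000 nM in this assay, at which 2 of the 3 values shown sit.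

Compound 3 `Oc1ccccc1-c1cc(-c2ccccn2)cc(-c2ccccc2O)n1` has a different core; the difference between the core of compound 3 and the core of compound 1 is not broken down here. In this assay compound 3 gives only a limit of the assay, > 50000 nM. Compound 4 `Oc1cccc(-c2cc(-c3ccccn3)cc(-c3ccccc3O)n2)c1` is not yet measured. The change from compound 3 to compound 4 is 3-hydroxyphenyl in place of 2-hydroxyphenyl on an aromatic carbon, the same kind of change as from compound 1 to compound 2, though here the place is meta to a 2-hydroxyphenyl group and a pyridin-2-yl group rather than a 4-hydroxyphenyl group and a furan-2-yl group. Since compound 3 sits at a limit, the step can only be estimated from the earlier one; he expects an at least 12-fold lower number from compound 3 to compound 4 (1.09 log units; beyond the scatter). For compound 4 his estimate in this assay is 4000 nM, between 800 nM and 30000 nM.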

Compound 4, half-maximal inhibitory concentration: 17100 nM
Beside the measured number, compound 4's estimate is 4.3-fold (0.63 log units) below it; low and high end bracket the measured number.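

In this assay, 3-hydroxyphenyl in place of 2-hydroxyphenyl again lowers the number, an at least 2.9-fold lower number from compound 3 to compound 4 (0.46 log units; beyond the scatter), so the direction of the change carries over from the core of compound 1 to the core of compound 3. Set side by side, the two steps read as follows: the same change on two cores in this assay, an at least 24-fold lower number (1.38 log units; beyond the scatter) from compound 1 to compound 2 and an at least 2.9-fold lower number (0.46 log units; beyond the scatter) from compound 3 to compound 4; the limit leaves it open whether they differ. Going by these compounds, what this does not show is how large the step truly is on either core, since each starting compound stands at a limit and the real size of each step stays unknown: the limit of > 50000 nM in this assay, at which 2 of the 4 values shown sit.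

The compounds shown leave open whether a methoxy group, an amine or a carboxylic acid in place of the hydroxyl on the 3-hydroxyphenyl group would keep the lower number in this assay. They also leave open whether the same change would carry over to a third core, or to the remaining 2-hydroxyphenyl group of compound 4.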